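This account rests on a few compounds, and the source may have more. Where it says the series, first, only, none or still open, it means among the compounds named here.

Of the compounds shown here, three built on a shared core have so far been measured in an assay on isolated protein for inhibition of DNA topoisomerase 1 (Homo sapiens), with a stated time of 15 min; on this read-out lower numbers stand for stronger inhibition and higher numbers for weaker inhibition. Compound 1 `COc1c(N2CC[C@@H](N)C2)c(F)cc2c(=O)c(C(=O)O)cn(Cc3ccc(-c4ccccc4)cc3)c12` gives 92200 nM in this assay. Compound 2 `NCCNc1cc2c(cc1F)c(=O)c(C(=O)O)cn2Cc1ccc(-c2ccccc2)cc1` gives 72800 nM in this assay. Compound 3 `CNCCCNc1c(F)cc2c(=O)c(C(=O)O)cn(Cc3ccc(-c4ccccc4)cc3)c2c1OC` gives 101000 nM in this assay. For the measured compounds named here, all three numbers lie within the usual scatter of one another: the only step between compounds that differ in one place, a 1.1-fold higher number from compound 1 to compound 3 (0.04 log units; within the scatter), is within the scatter, and the gap between compound 2 and compound 3 is smaller than the scatter as well, so none of the three can be called stronger or weaker than another.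

Compound 4 `COc1c(NCCN)c(F)cc2c(=O)c(C(=O)O)cn(Cc3ccc(-c4ccccc4)cc3)c12` has not yet been measured. It differs from compound 3 by amino in place of (methylamino)methyl on a saturated chain carbon, two bonds along the chain from a nitrogen on an aromatic ring. Going by the values given here, the one measured step that touches this part of the molecule, a 1.1-fold higher number from compound 1 to compound 3 (0.04 log units; within the scatter), also reshaped the group on that aromatic nitrogen and moved the number by less than the scatter. Compound 4 also shares its (2-aminoethyl)amino chain with compound 2, which gives 72800 nM. Among the compounds with values here, nothing measured so far points to a move beyond the scatter. The step of a 1.2-fold lower number from compound 3 to compound 4 (0.07 log units; within the scatter) is therefore expected to stay within the scatter. The estimate for compound 4 is 85000 nM, with a range from 40000 nM to 180000 nM.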

Compound 4, half-maximal inhibitory concentration: > 200000 nM
Compound 4 was reported as a limit; the forecaster's own chance of this, stated with the estimate: 10%; middle value at least 2.3-fold (0.37 log units) from the limit.
By their numbers in this assay, from the lowest: compounds 2, 1 and 3 (each within the scatter of the next). At a limit, above all of these: compound 4.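

Compound 4 is reported only as a limit, not as an exact number: the limit of > 200000 nM in this assay, at which 1 of the 4 values shown sits. Going from (3-(methylamino)propyl)amino to (2-aminoethyl)amino on the methoxy-bearing core gives an at least 1.9-fold higher number from compound 3 to compound 4 (0.29 log units; that floor lies within the scatter), so this change cannot yet be separated from repeat-measurement noise, although the true gap could be larger. The other two steps give the first differences in this set that clear the scatter: adding methoxy in place of hydrogen on an aromatic carbon gives an at least 2.7-fold higher number from compound 2 to compound 4 (0.43 log units; beyond the scatter), and (2-aminoethyl)amino in place of 3-aminopyrrolidin-1-yl on an aromatic carbon gives an at least 2.1-fold higher number from compound 1 to compound 4 (0.33 log units; beyond the scatter), which shows that sharing the (2-aminoethyl)amino chain does not ensure similar numbers and that the group on this aromatic carbon can matter.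

On these data alone, all three steps have only a lower bound, so their true sizes remain open, as does whether methoxy in place of hydrogen would have a similar effect with 3-aminopyrrolidin-1-yl or (3-(methylamino)propyl)amino. A (2-(methylamino)ethyl)amino chain would help separate the contribution of chain length from that of the methyl group on the amine, since the step from compound 3 to compound 4 changes both.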